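The source may report more compounds than this note shows. Statements on the series, on what has been measured and on what is new or still open speak of the compounds shown alone.

Series notes. Compound 1 `CC(C)C(Nc1nnc[nH]1)c1ccc(-c2ccc3cccc(F)c3c2)[nH]c1=O` gives 185 nM in a functional assay on CHO cells for antagonist activity at prostaglandin E2 receptor EP3 subtype (Homo sapiens), read by cAMP accumulation; a lower number here means a stronger inhibitor, a higher number a weaker inhibitor. Compound 2 `CC(C)C(c1ncco1)c1ccc(-c2ccc3cccc(F)c3c2)[nH]c1=O` gives 64 nM in this assay, and compound 3 `CC(C)C(Cc1nnc[nH]1)c1ccc(-c2ccc3cccc(F)c3c2)[nH]c1=O` gives 17 nM. Compound 3 stands lowest of the three numbers; its nearest neighbour is compound 2 and the furthest is compound 1. The steps run a 2.9-fold lower number from compound 1 to compound 2 (0.46 log units; beyond the scatter), a 3.8-fold lower number from compound 2 to compound 3 (0.58 log units; beyond the scatter) and an 11-fold lower number from compound 1 to compound 3 (1.04 log units; beyond the scatter).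

Compound 4 `Cc1nc(C(c2ccc(-c3ccc4cccc(F)c4c3)[nH]c2=O)C(C)C)[nH]c1C` is not yet measured. It differs from compound 3 in one place: 4,5-dimethyl-1H-imidazol-2-yl in place of (4H-1,2,4-triazol-3-yl)methyl on a saturated chain carbon bound to an aromatic carbon and a saturated chain carbon. Among the compounds with values here, no measured step repeats this change. The closest comparison is compound 2, which also carries a five-membered aromatic ring directly on that chain carbon, and the step of a 3.8-fold lower number from compound 2 to compound 3 (0.58 log units; beyond the scatter) shows that inserting a methylene with a triazole gave a lower number. Compound 4 keeps a hydrogen-bond donor on its ring, unlike compound 2, so a step back toward compound 2 is expected but not the full size of that step. The number for compound 4 in this assay is therefore expected to be modestly higher than for compound 3, as a 2.4-fold higher number from compound 3 to compound 4 (0.37 log units; beyond the scatter). The estimate for compound 4 is 40 nM, with a range of 12 nM to 130 nM.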

Compound 4, half-maximal inhibitory concentration: 50 nM
Compound 4: middle estimate off by 1.3-fold (0.10 log units), on the low side; the range from low to high includes it.
By their numbers in this assay, from the lowest: compound 3; then compounds 4 and 2 (each within the scatter of the next); then compound 1.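

In this assay the 4,5-dimethyl-1H-imidazol-2-yl and 1,3-oxazol-2-yl groups cannot be told apart with the ring directly on the saturated chain carbon. The step is a 1.3-fold lower number from compound 2 to compound 4 (0.11 log units; within the scatter) and this change of ring does not move the number beyond the scatter. Compound 3 remains the lowest of the four, with a 2.9-fold higher number from compound 3 to compound 4 (0.47 log units; beyond the scatter) as the cost of replacing its (4H-1,2,4-triazol-3-yl)methyl group. Compound 1 remains the highest, and a 3.7-fold lower number from compound 1 to compound 4 (0.57 log units; beyond the scatter) places the new group clear of the (4H-1,2,4-triazol-3-yl)amino group.

No measurement in hand gives a cause for these steps. Open, as far as these compounds go, is whether the two methyl groups contribute, and whether an unsubstituted imidazol-2-yl group or an imidazol-2-ylmethyl group would read with compound 4 or with compound 3.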